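Urea-linked anilines on a quinazoline amine scaffold: antiproliferative notes

The source may hold more compounds than are shown below. What is called first, only, known or untested is meant among the compounds shown, and "the series" means these compounds.

Measured compounds:
compound 1 `COc1ccccc1NC(=O)Nc1cccc(CNc2ncnc3ccccc23)c1`, 30800 nM
compound 2 `COc1ccc(NC(=O)Nc2cccc(CNc3ncnc4ccccc34)c2)cc1`, 29300 nM

In a functional assay on A549 cells (Homo sapiens) for antiproliferative activity, read by MTT assay (a higher number here means a weaker inhibitor, a lower number a stronger inhibitor), compound 1 gives 30800 nM and compound 2 gives 29300 nM. Compound 2 holds the lower of the two numbers, but the step of a 1.1-fold lower number from compound 1 to compound 2 (0.02 log units; within the scatter) is within the scatter, so the two cannot be ordered against each other. Moving the methoxy from the 2-position to the 4-position of the phenyl on the urea nitrogen thus changed nothing that can be read.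

Compound 3 `O=C(Nc1cccc(CNc2ncnc3ccccc23)c1)Nc1ccccc1Cl` is not yet measured. It differs from compound 2 in that (2-chlorophenyl in place of 4-methoxyphenyl on an amide-type nitrogen). Going by the values given here, no measured step exchanges methoxy for chlorine, so the only step that bears on this change is the positional one, a 1.1-fold lower number from compound 1 to compound 2 (0.02 log units; within the scatter), which was flat. With no evidence that the substituent on this phenyl moves the number, compound 3 is expected to stay near compound 2, with a 1.0-fold higher number from compound 2 to compound 3 (0.01 log units; within the scatter) as the estimated step and no direction beyond the scatter. The estimate for compound 3 in this assay is 30000 nM, with a range from 10000 nM to 100000 nM.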

Compound 3, half-maximal inhibitory concentration: 18000 nM
For compound 3 the middle estimate is 1.7-fold (0.22 log units) above the measured one, within the range that was stated.
By their numbers in this assay, from the lowest: compounds 3, 2 and 1 (each within the scatter of the next).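

Going by these compounds alone, compound 3 brings the first exchange of the substituent itself rather than its place. In this assay, 2-chlorophenyl in place of 4-methoxyphenyl on an amide-type nitrogen gives a 1.6-fold lower number from compound 2 to compound 3 (0.21 log units; within the scatter), a comparison in which both the substituent and its place on the phenyl differ. The narrower exchange of chloro in place of methoxy on an aromatic carbon gives a 1.7-fold lower number from compound 1 to compound 3 (0.23 log units; within the scatter), so neither step separates the compounds, and with the flat positional step already noted, compounds 1, 2 and 3 cannot be ordered against each other; no measurement at hand bears on the reason for these numbers.

Still open, as far as these compounds go, is whether any change on this phenyl can move the number beyond the scatter, for example an amine or a carboxylic acid on the ring, or a longer chain in place of the methoxy. Also open, from the compounds shown here alone, is how 4-chlorophenyl on the same amide-type nitrogen would read, which would separate the place of the chloro from its identity in a single step.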